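A few compounds are considered here, and "the series" means these few. Any claim that something is new, unique, unknown or untested is made for them only; others in the source may bear on it.

Of the compounds shown here, three built on a shared core have been measured in an assay on NIH3T3 cells with Urotensin-2 receptor (Homo sapiens) as the target; a higher number here means that more compound is needed for the effect, a lower number that less compound is needed. Compound 1 `Cc1ccsc1C(=O)OC(CCN(C)C)c1ccc(Cl)cc1` gives 2510 nM. Compound 2 `CCc1ccccc1C(=O)N[C@@H](CCN(C)C)c1ccc(Cl)cc1` gives 1020 nM, a lower number that lies beyond the usual scatter of repeated measurements. Compound 3 `Cc1cccc(C(=O)NC(CCN(C)C)c2ccc(Cl)cc2)c1C` gives 3630 nM, which sits within the scatter of the number for compound 1. On these three numbers compound 1 holds the second highest place, indistinguishable from compound 3 and clearly apart from compound 2.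

Compound 4 `Cc1ccccc1NC(=O)OC(CCN(C)C)c1ccc(Cl)cc1` has not yet been measured. It differs from compound 1 in one place: (2-methylphenyl)amino in place of 3-methylthiophen-2-yl on a carbonyl carbon. Within the data shown here, no pair of measured compounds records an exchange of this kind, so the expectation rests only on the spread of numbers already seen. The step from compound 1 to compound 4 is expected to be modest, a 1.6-fold lower number from compound 1 to compound 4 (0.20 log units; within the scatter), most likely not beyond the scatter, with a slight lean toward a lower number. For compound 4 the estimated value in this assay is 1600 nM, within a range from 400 nM to 6500 nM.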

Compound 4, half-maximal effective concentration: 3890 nM
Compound 4: middle estimate off by 2.4-fold (0.39 log units), on the low side, and the stated range covers the measured number.
By their numbers in this assay, from the lowest: compound 2; then compounds 1, 3 and 4 (each within the scatter of the next).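

Putting (2-methylphenyl)amino in place of 3-methylthiophen-2-yl on a carbonyl carbon gives a 1.5-fold higher number from compound 1 to compound 4 (0.19 log units; within the scatter) in this assay. Among these compounds, this is the first single-place comparison, and it shows that this position can take a different group with no change that can be told from the scatter: a six-membered carbon ring replaces a five-membered ring holding sulfur, and a hydrogen-bond donor is gained while an acceptor is lost. No measurement on hand says why the number holds steady across this exchange.

From the compounds shown here alone, this single step changes the ring and the linking amino nitrogen together, so their separate contributions remain unknown. Also open, going by these compounds, is whether a group without a ring at this place, such as a plain amine or a longer alkyl chain, would give a similar number.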